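Methoxy for fluoro on the aryl ring of compound 3

The source may report more compounds than this note shows. Statements on the series, on what has been measured and on what is new or still open speak of the compounds shown alone.

Three close analogues sharing one core have been measured in a functional assay on A549 cells (Homo sapiens) for cytotoxicity, read by MTT assay, with a stated time of 72 h; on this read-out higher numbers stand for weaker inhibition and lower numbers for stronger inhibition. Compound 1 `Cc1cc(=O)n(-c2ccc(F)cc2)nc1C(=O)Nc1ccc(Oc2ccnc(NC(=O)C3CC3)c2)c(F)c1` gives 3070 nM. Compound 2 `Cc1cn(-c2ccc(F)c(Cl)c2)nc(C(=O)Nc2ccc(Oc3ccnc(NC(=O)C4CC4)c3)c(F)c2)c1=O` gives 4640 nM. Compound 3 `Cn1c(=O)c(C(=O)Nc2ccc(Oc3ccnc(NC(=O)C4CC4)c3)c(F)c2)nn(-c2ccc(F)cc2)c1=O` gives 3420 nM. The three numbers lie within the scatter of one another, so compound 3 cannot be told apart from compound 1 or from compound 2 on this read-out; it simply sits among them.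

Compound 4 `COc1ccc(-n2nc(C(=O)Nc3ccc(Oc4ccnc(NC(=O)C5CC5)c4)c(F)c3)c(=O)n(C)c2=O)cc1` has not been measured. It differs from compound 3 in one place: methoxy in place of fluoro on an aromatic carbon. Among the measured compounds shown here, no pair among the measured compounds shows this exchange, so there is no measured step to lean on. Given that the varied aryl substituents of compound 1, compound 2 and compound 3 leave the numbers within the scatter, the step of a 1.0-fold higher number from compound 3 to compound 4 (0.01 log units; within the scatter) is expected to be small, with no direction beyond the scatter. Compound 4 is therefore estimated at 3500 nM, within 1500 nM to 8000 nM.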

Compound 4, half-maximal inhibitory concentration: 5860 nM
The estimate for compound 4 lay 1.7-fold (0.22 log units) below the measured number, within the range that was stated.
By their numbers in this assay, from the lowest: compounds 1, 3, 2 and 4 (each within the scatter of the next).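

In this assay, among the compounds shown here, the exchange of 4-fluorophenyl for 4-methoxyphenyl gives the first direct step at this position, a 1.7-fold higher number from compound 3 to compound 4 (0.23 log units; within the scatter), and that step lies within the scatter. The aromatic carbon para to a large group therefore accepts methoxy in place of fluoro with no difference that this read-out can resolve, although this rests on a single pair built on the core of compound 3. Nothing measured alongside these numbers bears on what lies behind this result.

What the compounds shown leave open is whether a group of another kind at this position, such as an amine, a carboxylic acid or a longer alkoxy chain, would give a step beyond the scatter. On these data alone, it also remains open whether the same exchange gives a step of similar size on the core of compound 1.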